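Moving the pyridine nitrogen on a shared core

The compounds below may be only part of what the source reports. "The series", "measured", "known", "first", "only" and "open" are said of these compounds alone.

Of the compounds shown here, two have been measured in a functional assay (Homo sapiens) for antiproliferative activity; a lower number here means a stronger inhibitor of growth, a higher number a weaker inhibitor of growth. Compound 1 `Cc1cn2c(/C=N/NC(=N)N)c(-c3ccncc3)nc2s1` gives 39800 nM, the lowest of the two numbers, while compound 2 `Cc1sc2nc(-c3ccncc3)c(/C=N/NC(=N)N)n2c1C` gives 83200 nM in this assay. Within the data shown here, the one step between them, a 2.1-fold higher number from compound 1 to compound 2 (0.32 log units; beyond the scatter), arises from a methyl in place of hydrogen on an aromatic carbon, and is the only change for which a measured step exists.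

Compound 3 `Cc1cn2c(/C=N/NC(=N)N)c(-c3cccnc3)nc2s1` has not been measured. It differs from compound 1 as follows: pyridin-3-yl in place of pyridin-4-yl on an aromatic carbon. Among the measured compounds shown here, no measured step bears on this change; the step from compound 1 to compound 2 concerns a different part of the core and says nothing about where the pyridine nitrogen sits. For the measured compounds named here, with no guide beyond the pair measured, the step from compound 1 to compound 3 in this assay is expected to be a 1.0-fold higher number from compound 1 to compound 3 (0.00 log units; within the scatter), that is, nothing clearly beyond the scatter in either direction. Compound 3 is therefore estimated to give 40000 nM in this assay, within a range from 10000 nM to 160000 nM.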

Compound 3, concentration for total growth inhibition: 25700 nM
The estimate for compound 3 lay 1.6-fold (0.19 log units) above the measured number, and the stated range covers the measured number.
By their numbers in this assay, from the lowest: compounds 3 and 1 (each within the scatter of the next); then compound 2.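

In this assay, exchanging pyridin-4-yl for pyridin-3-yl on this aromatic carbon gives a 1.5-fold lower number from compound 1 to compound 3 (0.19 log units; within the scatter), so the read-out does not separate these two placements of the pyridine nitrogen. Among these compounds, this is the first measured change at this position, as the earlier step concerned a methyl elsewhere on the core, and it shows that the pyridine ring can carry its nitrogen in either placement without a difference beyond the scatter. Nothing available accounts for this result, and the data give no reason why the two placements read alike.

The compounds shown cannot say whether the ring nitrogen is needed at all on this carbon, since every one of them carries a pyridine here, and only a plain phenyl or a pyridin-2-yl group in the same place would test that. They also leave open whether the added methyl of compound 2 would have the same effect on the pyridin-3-yl series, which a compound combining both changes would settle.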